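A few compounds are considered here, and "the series" means these few. Any claim that something is new, unique, unknown or untested is made for them only; others in the source may bear on it.

In an in vitro ADME assay on microsomes from liver (Rattus norvegicus) for metabolic stability (on this read-out higher numbers stand for fast clearance and lower numbers for slow clearance), compound 1 `Cc1ccc(Cn2c(=O)[nH]c3c(N)nc(-c4ncco4)cc32)cn1` gives < 8.5 mL.min-1.g-1 as a limit of the assay and not a number. Compound 2 `Cc1cccc(Cn2c(=O)[nH]c3c(N)nc(C(F)(F)F)cc32)n1` gives a measured 27 mL.min-1.g-1 on the same read-out. Compound 3 `Cc1nc(Cn2c(=O)[nH]c3c(N)nc(C(F)(F)F)cc32)cs1` gives < 10 mL.min-1.g-1 as a limit too, so its true value is not known. Within the data shown here, the one measured step at the place that matters here is an at least 2.7-fold lower number from compound 2 to compound 3 (0.43 log units; beyond the scatter) and it lies beyond the scatter. Compound 4 `Nc1ccc(Cn2c(=O)[nH]c3c(N)nc(C(F)(F)F)cc32)cn1` differs from compound 3 at that same place, as follows: 6-aminopyridin-3-yl in place of 2-methyl-1,3-thiazol-4-yl on a saturated chain carbon bound to an aromatic nitrogen on the shared core. This brings back a pyridine ring, and compound 2 at 27 mL.min-1.g-1 serves as the upper guide for such a ring. Compound 1 also carries a pyridine ring and reports only a limit, though it differs elsewhere too, so only a modest rise is expected in this assay overall. The expected change is an at least 1.5-fold higher number from compound 3 to compound 4 (0.17 log units; that floor lies within the scatter) in this estimate. For compound 4 the estimated value is 15 mL.min-1.g-1 with an expected range from 6 mL.min-1.g-1 to 35 mL.min-1.g-1 in the measurement to come.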

Compound 4, intrinsic clearance in microsomes: < 10 mL.min-1.g-1
Compound 4: no number, only a limit; the forecaster's own chance of this, stated with the estimate: 35%; at least 1.5-fold (0.17 log units) between middle value and limit.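

In this assay compound 4 gives < 10 mL.min-1.g-1, a limit of the assay and not a number. Until now only 2-methyl-1,3-thiazol-4-yl had given a lower number at this place on a saturated chain carbon bound to an aromatic nitrogen, but 6-aminopyridin-3-yl, a six-membered aromatic ring with 1 hetero atom, now gives an at least 2.7-fold lower number from compound 2 to compound 4 (0.43 log units; beyond the scatter), so a six-membered aromatic ring here need not carry a high number. The step from compound 3 to compound 4 cannot be read, because both values sit at one limit: the limit of < 10 mL.min-1.g-1 in this assay, at which 2 of the 4 values shown sit.

Going by these compounds, how far the true values of compound 3 and compound 4 lie under that limit stays open, so these two groups cannot be ranked. On these data alone, it is also open whether a plain pyridin-3-yl group or a 6-methoxypyridin-3-yl group at this place would reach the same limit in this assay.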